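The compounds below may be only part of what the source reports. "The series", "measured", "known", "first", "only" and "open" are said of these compounds alone.

Compound 1 `Cc1nc(NCCOC(C)C)nc(N[C@@H]2C[C@H](CO)[C@@H](O)[C@H]2O)c1-c1nc2ccccc2s1`: in an ADME assay on cells (Homo sapiens) for cytotoxicity, read by polymerase chain reaction, with a stated time of 3 days (a lower number here means that less compound is tolerated, a higher number that more compound is tolerated), compound 1 gives 8000 nM.
Compound 2 `Cc1nc(Nc2ccccc2)nc(N[C@@H]2C[C@H](CO)[C@@H](O)[C@H]2O)c1-c1nc2ccccc2s1`: in this assay compound 2 gives > 25000 nM, a limit of the assay.

Compound 2 therefore stands at the limit of > 25000 nM in this assay, at which 1 of the 2 values shown sits, with no exact number known. Compound 3 `Cc1nc(NCc2cccs2)nc(N[C@@H]2C[C@H](CO)[C@@H](O)[C@H]2O)c1-c1nc2ccccc2s1` differs from compound 2 by (thiophen-2-yl)methyl in place of phenyl on a nitrogen on an aromatic ring. Among the measured compounds shown here, the only measured step that bears on this position, an at least 3.1-fold higher number from compound 1 to compound 2 (0.49 log units; beyond the scatter), went from a number to a limit when an aromatic ring replaced a chain. The new change keeps an aromatic ring but adds a linker, so the expected step is an at least 1.6-fold lower number from compound 2 to compound 3 (0.22 log units; that floor lies within the scatter), a modest move back toward a measurable number. Compound 3 is estimated at 15000 nM, within 5000 nM to 40000 nM.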

Compound 3, half-maximal cytotoxic concentration: 6000 nM
Compound 3: the middle estimate sits 2.5-fold (0.40 log units) above what was measured; the measured number falls inside the stated range.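

Placing (thiophen-2-yl)methyl on this nitrogen in place of phenyl gives an at least 4.1-fold lower number from compound 2 to compound 3 (0.61 log units; beyond the scatter), so high tolerance here does not extend to every group carrying an aromatic ring. That step is only a floor, because one end of it is a limit of the assay: the limit of > 25000 nM in this assay, at which 1 of the 3 values shown sits. Set against the 2-isopropoxyethyl chain, the same group gives a 1.3-fold lower number from compound 1 to compound 3 (0.12 log units; within the scatter), so having a ring does not by itself separate it from that chain.

As far as these compounds go, this change swaps the ring and adds a linking carbon at once, and which of the two matters stays open. A benzyl group on this nitrogen would tell them apart.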